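Amide to larger ester group: expected step

The source may hold more compounds than are shown below. What is called first, only, known or untested is meant among the compounds shown, and "the series" means these compounds.

In a functional assay on HCT-116 cells (Homo sapiens) for inhibition, read by MTT assay, with a stated time of 48 h (a higher number here means a weaker inhibitor, a lower number a stronger inhibitor), compound 1 (`COc1ccc(N(C)c2nc(C)nc3ccccc23)cc1C(=O)OCC[Se]C#N`) gives 951 nM and compound 2 (`COc1ccc(N(C)c2nc(C)nc3ccccc23)cc1C(=O)NCC[Se]C#N`) gives 313 nM as the lower of the two numbers. Compound 3 (`COc1ccc(N(C)c2nc(C)nc3ccccc23)cc1C(=O)OCCCCCC[Se]C#N`) departs from compound 2 on a carbonyl carbon, with a group of 10 heavy atoms (7 carbon, 1 nitrogen, 1 oxygen, 1 selenium; no ring) in place of a group of 6 heavy atoms (3 carbon, 2 nitrogen, 1 selenium; no ring), on a carbonyl carbon as the change. Within the data shown here, the only measured guide is a 3.0-fold lower number from compound 1 to compound 2 (0.48 log units; beyond the scatter) for the ester-to-amide change, so a return to an ester points to a higher number of modest size. Among the measured compounds shown here, no measured compound shows what the larger group alone does. Expected here is a 2.2-fold higher number from compound 2 to compound 3 (0.35 log units; beyond the scatter) as an estimate. Compound 3 is estimated at 700 nM within 200 nM to 2500 nM as its range.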

Compound 3, half-maximal inhibitory concentration: 1990 nM
Compound 3: the middle estimate sits 2.8-fold (0.45 log units) below what was measured; the range from low to high includes it.
By their numbers in this assay, from the lowest: compound 2; then compound 1; then compound 3.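

In this assay, the ester pair separates the larger group from the change of linking atom: lengthening the chain alone gives a 2.1-fold higher number from compound 1 to compound 3 (0.32 log units; beyond the scatter), so the longer chain carries a cost at this position even with the ester held constant. The whole change on the carbonyl carbon gives a 6.4-fold higher number from compound 2 to compound 3 (0.80 log units; beyond the scatter). No measurement at hand accounts for either step. On these data alone, whether the amide keeps its lower number when it carries the longer chain remains open. So does the outcome with a chain of intermediate length or a carboxylic acid on the carbonyl carbon.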